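A few compounds are considered here, and "the series" means these few. Any claim that something is new, unique, unknown or untested is made for them only; others in the source may bear on it.

Compound 1 `N=C(N)c1ccc(-c2ccc(-c3ccc(Cl)cc3)s2)s1`: 1570 nM
Compound 2 `N=C(N)c1ccc(-c2ccc(-c3cncc4ccccc34)s2)s1`: 1530 nM
Compound 3 `N=C(N)c1ccc(-c2ccc(-c3ccc4ccccc4c3)s2)s1`: 2020 nM

In a functional assay on HCC 2998 cells (Homo sapiens) for inhibition, read by sulforhodamine B assay, with a stated time of 48 h (on this read-out higher numbers stand for weaker inhibition of growth and lower numbers for stronger inhibition of growth), compound 1 gives 1570 nM, the second highest of the three numbers. Compound 2 gives 1530 nM and compound 3 gives 2020 nM; both differences from compound 1 lie within the usual scatter, so the three compounds cannot be told apart on these numbers. Compound 4 `N=C(N)c1ccc(-c2ccc(-c3ccc(F)cc3)s2)s1` has not yet been measured in this assay. It differs from compound 1 in one place: fluoro in place of chloro on an aromatic carbon. Within the data shown here, no pair of measured compounds differs in one place, so the data give no step to lean on for this change. The expected step, a 1.0-fold higher number from compound 1 to compound 4 (0.01 log units; within the scatter), is none beyond the scatter. Compound 4 is therefore estimated at 1600 nM, within a range of 800 nM to 3200 nM.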

Compound 4, concentration for 50% growth inhibition: 1730 nM
Estimate against measurement, compound 4: 1.1-fold (0.03 log units) below; measured number inside the range.
By their numbers in this assay, from the lowest: compounds 2, 1, 4 and 3 (each within the scatter of the next).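

In this assay, fluoro in place of chloro on an aromatic carbon, para to a large group, gives a 1.1-fold higher number from compound 1 to compound 4 (0.04 log units; within the scatter). Among these compounds, this is the first comparison of compounds differing in one place, and it shows that at this position the exchange of one halogen for the other does not shift growth inhibition beyond the scatter. No measurement shown bears on why the two compounds read alike. The compounds shown leave open whether an amine, a hydroxy group or a carboxylic acid at this position would read differently from the two halogens.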